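The source may report more compounds than this note shows. Statements on the series, on what has been measured and on what is new or still open speak of the compounds shown alone.

Compound 2 `Cc1c(F)c(Oc2cccc(C(=N)N)c2)nc(Oc2cccc(C(=O)O)c2)c1F` belongs to a small set of compounds built on one shared core. In an assay on isolated protein for inhibition of serine protease 1 (Bos taurus) (a higher number here means a weaker inhibitor, a lower number a stronger inhibitor), compound 2 gives > 5000 nM, which is a limit of the assay rather than a number. Compound 1 `Cc1c(F)c(Oc2cccc(N)c2)nc(Oc2cccc(C(=N)N)c2)c1F` gives > 5000 nM in this assay, likewise a limit. Compound 3 `Cc1c(F)c(Oc2cccc(C(=N)N)c2)nc(Oc2cccc(-n3ccnc3)c2)c1F` gives 4800 nM in this assay. Across the set, (the limit of > 5000 nM in this assay, at which 2 of the 3 values shown sit), so compound 2 stands no stronger than anything shown. The change leading to compound 4 `Cc1c(F)c(Oc2cccc(CCC(=O)N(C)C)c2)nc(Oc2cccc(C(=N)N)c2)c1F` is 2-(dimethylcarbamoyl)ethyl in place of carboxy on an aromatic carbon. Within the data shown here, the only measured step starting from compound 2 is an at least 1.0-fold lower number from compound 2 to compound 3 (0.01 log units; that floor lies within the scatter), while a step that the two limits leave unreadable from compound 1 to compound 2. Neither shows a shift beyond the scatter, so none is expected here either: for compound 4 the expected step is a number no higher from compound 2 to compound 4 (the limit leaves the size open). Compound 4 is therefore estimated at 5000 nM, within 1500 nM to 20000 nM.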

Compound 4, inhibition constant: 4900 nM
Beside the measured number, compound 4's estimate is 1.0-fold (0.01 log units) above it; measured number inside the range.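

Putting in 2-(dimethylcarbamoyl)ethyl, a larger group with no hydrogen-bond donor, gives a 1.0-fold higher number from compound 3 to compound 4 (0.01 log units; within the scatter). The comparisons with the two compounds at a limit give an at least 1.0-fold lower number from compound 2 to compound 4 (0.00 log units; that floor lies within the scatter) and an at least 1.0-fold lower number from compound 1 to compound 4 (0.00 log units; that floor lies within the scatter), and these remain only floors because of that limit: the limit of > 5000 nM in this assay, at which 2 of the 4 values shown sit. This aromatic carbon, meta to a large group, has now carried four different groups without any shift shown beyond the scatter.

Going by these compounds, how far compound 1 and compound 2 lie past their limits stays open. So does whether an aminomethyl group, or a longer chain ending in a carboxylic acid, would change the number here.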